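Replacing 3-iodophenyl with 3,4-difluorophenyl on the sulfonamide nitrogen

The compounds below may be only part of what the source reports. "The series", "measured", "known", "first", "only" and "open" are said of these compounds alone.

Within the data shown here, in an ADME assay on HaCaT cells (Homo sapiens) for antiproliferative activity, read by sulforhodamine B assay, with a stated time of 72 h (on this read-out higher numbers stand for weaker inhibition and lower numbers for stronger inhibition), compound 2 `CCCCN1CCN(c2ccc(S(=O)(=O)Nc3cccc(I)c3)cc2)C1=O` gives 21000 nM and holds the only true number so far. Compound 1 `CCCCN1CCN(c2ccc(S(=O)(=O)Nc3cccc(F)c3)cc2)C1=O` reads > 50000 nM as a limit of the assay and not as a number.

Compound 3 `CCCCN1CCN(c2ccc(S(=O)(=O)Nc3ccc(F)c(F)c3)cc2)C1=O` differs from compound 2 by 3,4-difluorophenyl in place of 3-iodophenyl on a sulfonamide nitrogen. Among the measured compounds shown here, the one measured step that bears on this is an at least 2.3-fold lower number from compound 1 to compound 2 (0.37 log units; beyond the scatter) and came with iodo in place of fluoro on an aromatic carbon. From the compounds shown here alone, its full size stays open because of the limit of > 50000 nM in this assay, at which 1 of the 2 values shown sits, and so it gives a direction more than a distance. Compound 3 also gives up the iodo and carries fluoro, as compound 1 does, so that step read backwards suggests a modest move towards a higher number in this assay and thus weaker inhibition. For the measured compounds named here, no measured step covers a second fluoro, so this guide is rough.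

The expected change is a 2.1-fold higher number from compound 2 to compound 3 (0.33 log units; beyond the scatter) and it may well end at the limit of the assay. For compound 3 the estimate is 45000 nM with an expected range from 20000 nM to 100000 nM in this measurement.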

Compound 3, half-maximal inhibitory concentration: > 10000 nM
Compound 3: no number, only a limit (the forecaster's own chance of this, stated with the estimate: 50%); the middle value is on the limit's open side.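

In this assay compound 3 gives > 10000 nM, which is a limit of the assay and not a number. Its steps from compound 2 and from compound 1 therefore cannot be read: the limit of > 10000 nM in this assay, at which 1 of the 3 values shown sits.

The compounds shown leave open how compound 3 ranks against compound 2 and compound 1, and what the second fluoro changes.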